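Switching a methyl for a methoxyethyl ester on the biaryl

A few compounds are considered here, and "the series" means these few. Any claim that something is new, unique, unknown or untested is made for them only; others in the source may bear on it.

Measured so far:
Compound 1, `CCOc1ccc(-c2cccc(S(=O)(=O)N(C)C)c2)cc1`, 63%
Compound 2, `CCOc1ccc(-c2cccc(C)c2)cc1`, 54%

Both compounds share the same core and were tested in an assay on COS-7 cells for inhibition of patatin-like phospholipase domain-containing protein 2 (Mus musculus), tested at 200 uM; a lower number here means less inhibition, a higher number more inhibition at the concentration tested (going by the name of the read-out). Compound 1 gives 63%, and compound 2 gives 54%. Among the compounds with values here, compound 2 has the lowest of the two numbers, but the only step that separates it from compound 1, a number 9 percentage points lower from compound 1 to compound 2 (within the scatter), lies within the scatter, so the two values cannot be ranked against each other.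

The next compound, compound 3, has the structure `CCOc1ccc(-c2cccc(C(=O)OCCOC)c2)cc1`. It differs from compound 2 by (2-methoxyethoxy)carbonyl in place of methyl on an aromatic carbon. Within the data shown here, the one measured step that bears on this change is the one from the dimethylsulfamoyl compound to the methyl compound, a number 9 percentage points lower from compound 1 to compound 2 (within the scatter), in which a group of several heavy atoms with acceptors was traded for a single carbon without visible effect beyond the scatter. The present change goes the other way, from the methyl back to a larger group with three acceptors, so no step beyond the scatter is expected in this assay. Compound 3 is therefore estimated at 58%, with a range of 40% to 76%, which corresponds to an expected step of a number 4 percentage points higher from compound 2 to compound 3 (within the scatter).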

Compound 3, a percentage reported as inhibition, at one concentration (the size of the read-out at that concentration, not a potency): 89%
Compound 3: middle estimate off by 31 percentage points, on the low side; the whole stated range lies below it.
By their numbers in this assay, from the lowest: compounds 2 and 1 (each within the scatter of the next); then compound 3.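

The result shows that this position, on an aromatic carbon of a six-membered aromatic ring of carbon only, does respond to the group it carries in this assay, which the step between the earlier pair (a number 9 percentage points lower from compound 1 to compound 2 (within the scatter)) could not show. The (2-methoxyethoxy)carbonyl group stands clear of methyl (a number 35 percentage points higher from compound 2 to compound 3 (beyond the scatter)) and also of dimethylsulfamoyl (a number 26 percentage points higher from compound 1 to compound 3 (beyond the scatter)). Simply having more than a single carbon at this place therefore does not set the number, since compound 1 also carries a group of several atoms yet stays within the scatter of compound 2, while compound 3 stands beyond both.

The compounds shown leave open which part of the (2-methoxyethoxy)carbonyl group goes with the higher number, the carbonyl or the methoxyethyl chain, a question that a carboxylic acid, a methyl ester or a longer ether chain at the same place would address. They also leave open whether the order would hold as a potency, as the read-out comes from a single concentration. No measurement given here speaks to the reason for the step.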